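Lengthening a Chain on a Core With No Measured Activity

This account rests on a few compounds, and the source may have more. Where it says the series, first, only, none or still open, it means among the compounds named here.

Compound 1 `Cn1cc(C2=C(c3nn(CCn4ccnc4)c4ncccc34)C(=O)NC2=O)c2ccccc21` carries an imidazole-bearing chain on the core shared by all the compounds here. In a functional assay on SMMC-7721 cells (Homo sapiens) for antiproliferative activity, read by MTT assay, with a stated time of 48 h (on this read-out higher numbers stand for weaker inhibition and lower numbers for stronger inhibition), compound 1 gives only a limit, > 100000 nM, a boundary of the test rather than a measured number. Compound 2 `Cn1cc(C2=C(c3nn(CCCn4cccc4)c4ncccc34)C(=O)N(c3ccccc3)C2=O)c2ccccc21` likewise returns only a limit, > 100000 nM, in this assay. Compound 3 `Cn1cc(C2=C(c3nn(CCCN4CCCCC4)c4ncccc34)C(=O)N(c3ccc(Cl)cc3)C2=O)c2ccccc21` also stops at the limit, > 100000 nM, in this assay. So compound 1 stands where every value shown stands, at the limit of > 100000 nM in this assay, at which 3 of the 3 values shown sit, with no number below it that would separate any of the three.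

Compound 4 `Cn1cc(C2=C(c3nn(CCCCn4ccnc4)c4ncccc34)C(=O)NC2=O)c2ccccc21` differs from compound 1 in one place: 2-(1H-imidazol-1-yl)ethyl in place of 1H-imidazol-1-yl on a saturated chain carbon, two bonds along the chain from an aromatic nitrogen. Among the compounds with values here, because every compound in hand sits at the limit of > 100000 nM in this assay, at which 3 of the 3 values shown sit, there is no measured step to show whether this kind of lengthening moves the result in either direction. The expectation in this assay is therefore for no step beyond the scatter, with compound 4 most likely again returning a limit. On that basis the step from compound 1 to compound 4 is estimated as a step that the limit leaves unreadable from compound 1 to compound 4. The estimate for compound 4 in this assay is 150000 nM, expected to lie between 40000 nM and 600000 nM.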

Compound 4, half-maximal inhibitory concentration: 29200 nM
Compound 4: middle estimate off by 5.1-fold (0.71 log units), on the high side; the whole stated range lies above it.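

Swapping 1H-imidazol-1-yl for 2-(1H-imidazol-1-yl)ethyl on a saturated chain carbon, two bonds along the chain from an aromatic nitrogen, produces in this assay an at least 3.4-fold lower number from compound 1 to compound 4 (0.53 log units; beyond the scatter), so the length of this imidazole-bearing chain does change the read-out, by more than the usual scatter. Compound 1 gives > 100000 nM, which is a limit of the assay and not a number. Compound 4 is therefore the only compound shown that gives a measured number and so offers a foothold for later comparisons, while the others remain at the limit: the limit of > 100000 nM in this assay, at which 3 of the 4 values shown sit.

The compounds shown leave open whether a still longer chain, such as 5-(1H-imidazol-1-yl)pentyl, would lower the number further or whether the trend stops at compound 4, and a single step cannot define a trend. They also leave open whether a dimethylamino group or a carboxylic acid at the chain end could take the place of the imidazole, and compounds 2 and 3 differ from compound 4 in more than one place, so they cannot settle this.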